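The source may hold more compounds than are shown below. What is called first, only, known or untested is meant among the compounds shown, and "the series" means these compounds.

Measured compounds:
compound 1 `Cn1cnc(C(=O)N(Cc2ccc(F)c(C(F)(F)F)c2)[C@H]2C[C@H]3CNC[C@H]3C2)c1`: 1.71 nM
compound 2 `CC(C)Oc1cccc(CN(C(=O)c2cn(C)cn2)[C@H]2C[C@H]3CNC[C@H]3C2)c1`: 3.96 nM
compound 3 `COc1ccc(CN(C(=O)c2cn(C)cn2)[C@H]2C[C@H]3CNC[C@H]3C2)cc1OC1CCCC1`: a limit only, > 641 nM

In an assay on HEK293 cells for displacement of a labelled ligand from sodium- and chloride-dependent glycine transporter 1 (Homo sapiens) (a lower number here means a stronger inhibitor, a higher number a weaker inhibitor), compound 1 gives 1.71 nM, the lowest of the two numbers shown. Compound 2 gives 3.96 nM, a step beyond the scatter. For compound 3 the read-out is a limit and not a number: the limit of > 641 nM in this assay, at which 1 of the 3 values shown sits. Within the data shown here, no pair of measured compounds differs in a single place, so nothing measured here shows what a change of configuration does in this assay.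

Compound 4 `Cn1cnc(C(=O)N(Cc2ccc(F)c(C(F)(F)F)c2)[C@@H]2C[C@H]3CNC[C@H]3C2)c1` differs from compound 1 as follows: the two compounds have the same atoms and bonds and differ only in configuration as drawn: 1 of 3 stereo elements differ; a stereocentre at a saturated ring carbon is drawn r in compound 1 and s in compound 4. The step from compound 1 to compound 4 in this assay is expected to raise the number, beyond the scatter, by an 8.8-fold higher number from compound 1 to compound 4 (0.94 log units; beyond the scatter). Compound 4 is estimated at 15 nM, with a range from 2 nM to 150 nM.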

Compound 4, inhibition constant: 26.9 nM
The estimate for compound 4 lay 1.8-fold (0.25 log units) below the measured number; measured number inside the range.
By their numbers in this assay, from the lowest: compound 1; then compound 2; then compound 4. At a limit, above all of these: compound 3.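

In this assay, configuration at this saturated ring carbon clearly matters: going from r to s gives a 16-fold higher number from compound 1 to compound 4 (1.20 log units; beyond the scatter). This is the first comparison in the series that differs in one place, so the step can be assigned to that stereocentre alone and not to any substituent: the fact that compounds 1 and 4 differ only in the configuration as drawn

Still open, as far as these compounds go, is whether the r to s change costs as much with other substituents, such as a nitrile in place of trifluoromethyl. The effect of the other two stereo elements is also unresolved.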